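A few compounds are considered here, and "the series" means these few. Any claim that something is new, unique, unknown or untested is made for them only; others in the source may bear on it.

Compound 1 `CC(C)c1noc(C2CCN(C(=O)[C@@H]3CCCN(S(=O)(=O)c4ccc(S(=O)(=O)C(C)C)cc4)C3)CC2)n1` gives 50 nM in a functional assay on MIA PaCa-2 cells (Homo sapiens) for inhibition, read by MTT assay, with a stated time of 7 days; a lower number here means a stronger inhibitor, a higher number a weaker inhibitor.
Compound 2 `CC(C)c1noc(N2CCN(C(=O)[C@@H]3CCCN(S(=O)(=O)c4ccc(S(=O)(=O)C5CCC5)cc4)C3)CC2)n1` gives 70 nM.
Compound 3 `CC(C)c1noc(N2CCN(C(=O)[C@@H]3CCCN(S(=O)(=O)c4ccc(S(=O)(=O)C(C)C)cc4)C3)CC2)n1` gives 70 nM.

All three numbers lie within the usual scatter of one another, so compound 3 stands level with compound 2, and compound 1 is not separated from either. Compound 4 `CCC(CC)S(=O)(=O)c1ccc(S(=O)(=O)N2CCC[C@@H](C(=O)N3CCN(c4nc(C(C)C)no4)CC3)C2)cc1` is made from compound 3 by one change: pentan-3-yl in place of isopropyl on a sulfonyl sulfur. Among the compounds with values here, one measured step touches the same place, the swap from cyclobutyl to isopropyl on that sulfonyl sulfur, which gave no change at the digits printed from compound 2 to compound 3 (within the scatter). Since a change of that kind on this sulfur left the number where it was, a small alkyl enlargement there is expected to give at most a step within the scatter, a 1.1-fold higher number from compound 3 to compound 4 (0.03 log units; within the scatter). Compound 4 is therefore estimated at 75 nM, with a range from 35 nM to 160 nM.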

Compound 4, half-maximal inhibitory concentration: 50 nM
For compound 4 the middle estimate is 1.5-fold (0.18 log units) above the measured one; the range from low to high includes it.
By their numbers in this assay, from the lowest: compounds 1, 4, 2 and 3 (each within the scatter of the next).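

Pentan-3-yl, with 5 heavy atoms against 3 for isopropyl, gives a 1.4-fold lower number from compound 3 to compound 4 (0.15 log units; within the scatter) in this assay, and in place of cyclobutyl it gives a 1.4-fold lower number from compound 2 to compound 4 (0.15 log units; within the scatter), so neither step leaves the usual scatter. On this sulfonyl sulfur, then, a bigger branched chain is accepted as readily as the two smaller groups. Nothing shown here offers a reason for this flat result. As far as these compounds go, all three groups at this place contain only carbon and hydrogen, so the effect of a chain carrying an amine or a carboxylic acid on this sulfur remains open. From the compounds shown here alone, a longer straight chain there remains open too.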